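The source may report more compounds than this note shows. Statements on the series, on what has been measured and on what is new or still open speak of the compounds shown alone.

Measured in an ADME assay (liver, Mus musculus) for metabolic stability, using microsomes; on this read-out higher numbers stand for a longer-lived compound and lower numbers for a shorter-lived compound:
- compound 1 `C=CC(=O)Nc1cccc(CNc2nc(Nc3cnn(CCOC)c3)ncc2Cl)c1`: 0.055 h
- compound 2 `C=CC(=O)Nc1cccc(CNc2nc(Nc3cnn(CCOC(F)F)c3)ncc2Cl)c1`: 0.0433 h

Going by the values given here, with only two numbers to compare, compound 2 at 0.0433 h cannot be ranked, as it lies within the usual scatter of compound 1 at 0.055 h. Both numbers mark short-lived compounds in this assay.

The next compound, compound 3 `C=CC(=O)Nc1cccc(CNc2nc(Nc3cnn(C(C)(C)COC)c3)ncc2Cl)c1`, has not yet been measured. It changes the group on the ring nitrogen: 1-(methoxymethyl)-1-methylethyl in place of 2-(difluoromethoxy)ethyl on an aromatic nitrogen. In words, 1-(methoxymethyl)-1-methylethyl stands in place of 2-(difluoromethoxy)ethyl.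

Among the compounds with values here, only one measured step bears on this, a 1.3-fold lower number from compound 1 to compound 2 (0.10 log units; within the scatter). That step altered the same side chain and stayed within the scatter, but it swapped only the group on the oxygen. The carbons of the chain were left as they were, so the data do not test the new branched chain directly.

With so little evidence, no clear shift can be predicted, and only a small rise is expected, with wide uncertainty. The expected step is a 1.4-fold higher number from compound 2 to compound 3 (0.14 log units; within the scatter), which stays within the scatter. The estimated half-life of compound 3 is 0.06 h, with an expected range from 0.03 h to 0.16 h.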

Compound 3, half-life: 0.03 h
For compound 3 the middle estimate is 2.0-fold (0.30 log units) above the measured one; measured number inside the range.
By their numbers in this assay, from the lowest: compounds 3, 2 and 1 (each within the scatter of the next).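

In this assay, the newest change rebuilds the carbons of the chain on the aromatic nitrogen, where the earlier step altered only the group on its oxygen: putting 1-(methoxymethyl)-1-methylethyl in place of 2-(difluoromethoxy)ethyl gives a 1.4-fold lower number from compound 2 to compound 3 (0.16 log units; within the scatter), and putting it in place of 2-methoxyethyl gives a 1.8-fold lower number from compound 1 to compound 3 (0.26 log units; within the scatter). Even this larger rebuilding of the chain therefore leaves the half-life within the scatter of both earlier compounds, so the three side chains cannot be ranked and all three compounds remain short-lived. Nothing available here accounts for where these numbers fall.

From the compounds shown here alone, all three side chains are open chains that carry an ether oxygen, so it remains open whether a different kind of group on this nitrogen, such as a chain ending in an amine or a carboxylic acid, or a small saturated ring such as oxetane, would move the half-life beyond the scatter. Going by these compounds, it is also open whether this position has any real hold on the half-life, or whether other parts of the molecule matter more, such as the shared core or the groups attached to it.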